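The source may report more compounds than this note shows. Statements on the series, on what has been measured and on what is new or still open speak of the compounds shown alone.

Compound 1, with the structure `Cc1nc(C(NC(=O)C(=O)Nc2ccc(F)c(F)c2)C2CCCCN2)sc1CO`, was tested in an ADME assay on TZM-b1 cells (Homo sapiens) for cytotoxicity, read by XTT assay, with a stated time of 3 days; a lower number here means that less compound is tolerated, a higher number that more compound is tolerated. Compound 1 gives > 87000 nM there, which is a limit of the measurement rather than a number. Two related compounds were tested alongside it. Compound 2, with the structure `Cc1nc(C(NC(=O)C(=O)Nc2ccc(F)cc2)C2CCCCN2)sc1CCO`, gives > 88000 nM in this assay, again a limit. Compound 3, with the structure `CC(=O)N1CCCCC1C(NC(=O)C(=O)Nc1ccc(Cl)cc1)c1nc(C)c(CCO)s1`, gives > 84000 nM in this assay, also a limit. So all three compounds sit at the edge of what the measurement can report: one at the limit of > 84000 nM in this assay, at which 1 of the 3 values shown sits, one at the limit of > 87000 nM in this assay, at which 1 of the 3 values shown sits, one at the limit of > 88000 nM in this assay, at which 1 of the 3 values shown sits. Within the data shown here, compound 1 therefore stands at the same limit as the others, and none of the three is set apart from another; no pair of measured compounds differs in a single place, so no measured step is available.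

Compound 4, with the structure `Cc1nc(C(NC(=O)C(=O)Nc2ccc(Cl)c(F)c2)C2CCCCN2)sc1CO`, has not yet been measured in this assay. It differs from compound 1 by chloro in place of fluoro on an aromatic carbon, turning the 3,4-difluorophenyl group into a 4-chloro-3-fluorophenyl group. Given that compounds 1, 2 and 3 all stay at their limits, no step beyond the usual scatter is expected, and compound 4 is expected to give another limit. The estimated step from compound 1 is a number no higher from compound 1 to compound 4 (the limit leaves the size open). For compound 4 the expected value is 87000 nM, estimated to fall between 50000 nM and 150000 nM.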

Compound 4, half-maximal cytotoxic concentration: 58400 nM
Compound 4: the middle estimate sits 1.5-fold (0.17 log units) above what was measured, within the range that was stated.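

Among these compounds, compound 4 is the first compound here to give a number rather than a limit in this assay, and the change behind it is small: one heavy atom replaces one heavy atom on an aromatic carbon, ortho to a fluoro group and para to a large group, with no hydrogen-bond donor, hydrogen-bond acceptor or net charge entering or leaving. That swap gives an at least 1.4-fold lower number from compound 1 to compound 4 (0.17 log units; that floor lies within the scatter), and since this is only a floor, the true gap may be close to the usual scatter or well beyond it. Nothing shown accounts for why chloro at this position brings a measurable value where fluoro gives a limit.

The compounds shown leave open whether this reading is particular to chloro or whether a bromo or methyl group on the same aromatic carbon would also give a number rather than a limit. They also leave open whether the same swap would act alike on a core carrying a different side chain, since a single pair cannot show how far the result extends beyond compound 1 and compound 4.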